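The source may report more compounds than this note shows. Statements on the series, on what has been measured and on what is new or still open speak of the compounds shown alone.

Compound 3 `Nc1scc(CN2CCN(c3c(F)cccc3F)CC2)c1C(=O)c1ccc(Cl)cc1` carries the lowest of the three numbers in a functional assay on CHO cells with adenosine receptor A1 (Homo sapiens) as the target, read by cAMP accumulation and immunoassay, with a stated time of 6 min, tested at 0.01 uM (a lower number here means a stronger effect, a higher number a weaker effect of the compound at the concentration tested), though its nearest neighbour is within the scatter: compound 3 gives -12%, compound 1 `Nc1scc(CN2CCN(c3ccc(Cl)c(C(F)(F)F)c3)CC2)c1C(=O)c1ccc(Cl)cc1` gives -2.5% and compound 2 `Nc1scc(CN2CCN(c3cccnc3)CC2)c1C(=O)c1ccc(Cl)cc1` gives 3.2%. The steps among them are a number 9.5 percentage points lower from compound 1 to compound 3 (within the scatter) and a number 5.7 percentage points higher from compound 1 to compound 2 (within the scatter), both within the scatter, and a number 15.2 percentage points lower from compound 2 to compound 3 (beyond the scatter), a modest step beyond it. Compound 4 `Nc1scc(CN2CCN(c3c(F)cc(F)cc3F)CC2)c1C(=O)c1ccc(Cl)cc1` differs from compound 3 as follows.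

fluoro in place of hydrogen on an aromatic carbon

Going by the values given here, no measured step adds a fluoro to a ring already bearing fluoro; even exchange of the whole aryl group in the three steps moved the number little, so no step beyond the scatter is expected in this assay. Compound 4 is therefore expected to give -8%, between -25% and 10%, an expected step of a number 4 percentage points higher from compound 3 to compound 4 (within the scatter).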

Compound 4, a percentage reported as activity, at one concentration (the size of the read-out at that concentration, not a potency): 4.2%
Estimate against measurement, compound 4: 12.2 percentage points below; measured number inside the range.
By their numbers in this assay, from the lowest: compounds 3, 1, 2 and 4 (each within the scatter of the next, the first and the last beyond it).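

In this assay, one added fluoro, para to a large group on the 2,6-difluorophenyl ring, gives a number 16.2 percentage points higher from compound 3 to compound 4 (beyond the scatter), so a single atom at this position can move the number beyond the scatter. With a number 1 percentage points higher from compound 2 to compound 4 (within the scatter) and a number 6.7 percentage points higher from compound 1 to compound 4 (within the scatter), the 2,4,6-trifluorophenyl group cannot be told apart from pyridin-3-yl or 4-chloro-3-(trifluoromethyl)phenyl. No measurement at hand accounts for the step. Open, going by these compounds, is whether a chloro, a methoxy or an amine at this position on the 2,6-difluorophenyl ring would move the number as fluoro does.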